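One group exchanged on compound 2

A few compounds are considered here, and "the series" means these few. Any claim that something is new, unique, unknown or untested is made for them only; others in the source may bear on it.

Compound 1 `CCOC(=O)/C=C/C=C/C=C/c1ccc[nH]1`: > 10000 nM
Compound 2 `O=C(/C=C/C=C/C=C/c1ccc[nH]1)OCc1ccccc1`: > 10000 nM

Both entries come from a functional assay on Raji cells (Homo sapiens) for cytotoxicity, with a stated time of 72 h; on this read-out higher numbers stand for weaker inhibition and lower numbers for stronger inhibition. In this assay compound 2 gives > 10000 nM, which is a limit and not a number. Compound 2 therefore has no exact position: the limit of > 10000 nM in this assay, at which 2 of the 2 values shown sit. Among the measured compounds shown here, the only measured step is a step that the two limits leave unreadable from compound 1 to compound 2, so it offers no size to carry forward. Compound 3 `O=C(/C=C/C=C/C=C/C=C/c1[nH]ccc1Cl)OCc1ccccc1` differs from compound 2 in one group: a group of 8 heavy atoms (6 carbon, 1 nitrogen, 1 chlorine; one five-membered aromatic ring with 1 hetero atom) in place of a group of 5 heavy atoms (4 carbon, 1 nitrogen; one five-membered aromatic ring with 1 hetero atom), on a double-bonded chain carbon bound to a double-bonded chain carbon. For the measured compounds named here, no measured step covers this change, so no direction can be read from the data. With so little to go on, the expectation stays near the limit of compound 2 at > 10000 nM. For compound 3 the expected value in this assay is 10000 nM, with an estimated range of 2000 nM to 30000 nM.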

Compound 3, half-maximal inhibitory concentration: 6700 nM
Estimate against measurement, compound 3: 1.5-fold (0.17 log units) above, and the stated range covers the measured number.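

In this assay, among the compounds shown here, compound 3 is the first compound here to give an exact number and not a limit. The exchange gives an at least 1.4-fold lower number from compound 2 to compound 3 (0.17 log units; that floor lies within the scatter) and so shows no change beyond the scatter. The entering group brings a chlorine and a further double bond together, and limits still make up most of the values shown: the limit of > 10000 nM in this assay, at which 2 of the 3 values shown sit.

Which of these two additions matters stays open. So does whether a bromine or a methyl in place of the chlorine, or a longer chain, would move the number.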